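The source may hold more compounds than are shown below. What is called first, only, known or untested is meant among the compounds shown, and "the series" means these compounds.

Measured so far in a functional assay on the whole organism (strain Sprague-Dawley) for inhibition, with Rattus norvegicus as the target; on this read-out higher numbers stand for an effect only at larger amounts of compound and lower numbers for an effect already at smaller amounts:
compound 1, `O=c1c(-c2nn[nH]n2)c[nH]c2ccccc12`; in this assay compound 1 gives only a limit, > 20 mg/kg.
compound 2, `COc1cccc2c(=O)c(-c3nn[nH]n3)c[nH]c12`; compound 2 gives 0.312 mg/kg.
compound 3, `O=c1c(-c2nn[nH]n2)c[nH]c2c(C(F)(F)F)cccc12`; compound 3 gives only a limit, > 25 mg/kg.

Compound 3 thus stands at a limit and not at a number; of the three values two are limits (the limit of > 20 mg/kg in this assay, at which 1 of the 3 values shown sits, (the limit of > 25 mg/kg in this assay, at which 1 of the 3 values shown sits)) and only compound 2 carries a number. The step of an at least 80-fold higher number from compound 2 to compound 3 (1.90 log units; beyond the scatter) is large; the step of an at least 64-fold lower number from compound 1 to compound 2 (1.80 log units; beyond the scatter) is also large; the step that the two limits leave unreadable from compound 1 to compound 3 cannot be read between its two limits.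

Compound 4, `CCc1cccc2c(=O)c(-c3nn[nH]n3)c[nH]c12`, differs from compound 3 by ethyl in place of trifluoromethyl on an aromatic carbon. Only the changes at this carbon are measured: hydrogen and trifluoromethyl sit at limits, methoxy gives a number. Ethyl has no measured comparator, so the direction from compound 3 is open. The expectation for compound 4 is 5 mg/kg, with a range from 0.5 mg/kg to 50 mg/kg, and the step of an at least 5.0-fold lower number from compound 3 to compound 4 (0.69 log units; beyond the scatter) is expected to reflect this uncertain position.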

Compound 4, minimum effective dose: > 25 mg/kg
Compound 4: a limit, no number; the forecaster's own chance of this, stated with the estimate: 40%; middle value at least 5.0-fold (0.69 log units) from the limit.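

Compound 4 ends at a limit, not a number, and shares that limit with compound 3: the limit of > 25 mg/kg in this assay, at which 2 of the 4 values shown sit.

Among these compounds, the change from methoxy to ethyl gives an at least 80-fold higher number from compound 2 to compound 4 (1.90 log units; beyond the scatter), so among the groups at this carbon the loss of effect is not confined to the fluorine-bearing trifluoromethyl, and methoxy in compound 2 remains the only group here with a number. The steps from compound 1 and from compound 3 to compound 4 cannot be read, as each joins two limits.

From the compounds shown here alone, whether a number at this carbon is tied to methoxy alone stays open, and ethoxy, hydroxy or an amine here would test that. Going by these compounds, how far compound 1, compound 3 and compound 4 lie from their limits also stays open.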